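A larger group on the core of compound 3

The compounds below may be only part of what the source reports. "The series", "measured", "known", "first", "only" and "open" are said of these compounds alone.

Compound 3 `Cc1ccccc1-c1ncnc2c1C(=O)N(Cc1cc(C(F)(F)F)cc(C(F)(F)F)c1)C[C@H](C)CO2` gives 12.6 nM in a functional assay on ileum for antagonist activity at Substance-P receptor (Cavia porcellus); a lower number here means a stronger inhibitor, a higher number a weaker inhibitor. Within the data shown here, that number is the second highest of the three measured so far: compound 1 `Cc1ccccc1-c1ncnc2c1C(=O)N(Cc1cc(C(F)(F)F)cc(C(F)(F)F)c1)C[C@@H](C)CO2` gives 162 nM, and compound 2 `CC(=O)N1CCN(c2nc3c(c(-c4ccccc4C)n2)C(=O)N(Cc2cc(C(F)(F)F)cc(C(F)(F)F)c2)C[C@@H](C)CO3)CC1` gives 0.345 nM. Compounds 1 and 3 have the same atoms and bonds and differ only in configuration as drawn (the fact that compounds 1 and 3 differ only in the configuration as drawn), and the step of a 13-fold lower number from compound 1 to compound 3 (1.11 log units; beyond the scatter). The step of a 470-fold lower number from compound 1 to compound 2 (2.67 log units; beyond the scatter) shows what 4-acetylpiperazin-1-yl in place of hydrogen on an aromatic carbon does on the core of compound 1. Compound 4 `CC(=O)N1C(C)CN(c2nc3c(c(-c4ccccc4C)n2)C(=O)N(Cc2cc(C(F)(F)F)cc(C(F)(F)F)c2)C[C@H](C)CO3)CC1C` differs from compound 3 by a group of 11 heavy atoms (8 carbon, 2 nitrogen, 1 oxygen; one six-membered non-aromatic ring with 2 hetero atoms) in place of a hydrogen atom, on an aromatic carbon, placed between two ring nitrogen atoms; the entering group is not the same as that of compound 2, which carried no methyl groups on its added ring. The step from compound 1 to compound 2 bears most on this change, and on that basis a large step to a lower number is expected, written as a 110-fold lower number from compound 3 to compound 4 (2.02 log units; beyond the scatter). Compound 4 is estimated at 0.12 nM, within a range from 0.02 nM to 1.5 nM.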

Compound 4, antagonist equilibrium constant: 0.217 nM
Compound 4: middle estimate off by 1.8-fold (0.26 log units), on the low side; the measured number falls inside the stated range.
By their numbers in this assay, from the lowest: compounds 4 and 2 (each within the scatter of the next); then compound 3; then compound 1.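

In this assay, the group on the aromatic carbon between two ring nitrogen atoms gives a 58-fold lower number from compound 3 to compound 4 (1.76 log units; beyond the scatter). The earlier large step at this carbon stood only on the core of compound 1, whereas this one stands on the core of compound 3, so the number falls on both drawn configurations of the shared core: the fact that compounds 1 and 3 differ only in the configuration as drawn. The step also shows that a large drop at this carbon is not confined to the unmethylated ring of compound 2, as the ring entering compound 4 carries two methyl groups.

Compounds 2 and 4 differ in more than one place, which leaves the part played by those methyl groups open. As far as these compounds go, whether the acetyl group is needed also stays open, as does whether a free piperazine amine or a morpholine ring would lower the number as far.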